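Methoxy Replaces Chloro: From Compound 3 to Compound 4

The source may hold more compounds than are shown below. What is called first, only, known or untested is meant among the compounds shown, and "the series" means these compounds.

Of the compounds shown here, three have so far been measured in a functional assay on CCRF-CEM cells (Homo sapiens) for cytotoxicity, read by MTT assay, with a stated time of 72 h; on this read-out higher numbers stand for lower toxicity in this test and lower numbers for higher toxicity in this test. Compound 1 `N#C[Se]c1ccc(NC(=O)Oc2ccc(F)cc2)cc1` gives 71100 nM in this assay. Compound 2 `O=C(Nc1ccc([Se][Se]c2ccc(NC(=O)OCc3ccc([N+](=O)[O-])cc3)cc2)cc1)OCc1ccc([N+](=O)[O-])cc1` gives 68100 nM. Compound 3 `N#C[Se]c1ccc(NC(=O)Oc2ccc(Cl)cc2)cc1` gives 71800 nM, the highest of the three numbers, but its nearest neighbour is compound 1, whose number is within the scatter of it, and compound 2 stands within the scatter as well, so the three compounds sit together rather than in any order.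

Compound 4 `COc1ccc(OC(=O)Nc2ccc([Se]C#N)cc2)cc1` differs from compound 3 by methoxy in place of chloro on an aromatic carbon. For the measured compounds named here, one measured step bears on this change: a 1.0-fold higher number from compound 1 to compound 3 (0.00 log units; within the scatter), which shows that exchanging one small group on that aromatic carbon for another left this assay unmoved. Going by the values given here, no measured pair exchanges a halogen for a methoxy group, so the bearing is indirect, and the three numbers seen so far give no sign that this part of the structure shifts the read-out at all.

Compound 4 is therefore expected to show no step beyond the scatter, a 1.0-fold lower number from compound 3 to compound 4 (0.01 log units; within the scatter). The estimated value for compound 4 in this assay is 70000 nM, with a range from 35000 nM to 140000 nM.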

Compound 4, concentration lethal to 50% of the cells: 70000 nM
Compound 4: the middle estimate sits on the measured number at the digits printed, within the range that was stated.
By their numbers in this assay, from the lowest: compounds 2, 4, 1 and 3 (each within the scatter of the next).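

Up to this point the only exchange on this aromatic carbon was chloro for fluoro, a swap of one halogen for another. Methoxy is a group of a different kind, carrying a hydrogen-bond acceptor where chloro carries none, yet this assay shows a 1.0-fold lower number from compound 3 to compound 4 (0.01 log units; within the scatter) and likewise a 1.0-fold lower number from compound 1 to compound 4 (0.01 log units; within the scatter) when methoxy takes the place of fluoro. At this place, para to a large group, the read-out therefore stays within the scatter across fluoro, chloro and methoxy, so the flat result is no longer confined to halogens, and nothing at hand offers any explanation for why these exchanges leave the number unmoved.

What a carboxylic acid, an amine or a longer chain would do on this same aromatic carbon stays open, since all three groups shown here are small and uncharged. These steps also touch only this one position, so they leave unanswered which part of the shared core, if any, governs the level of the read-out.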